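The source may report more compounds than this note shows. Statements on the series, on what has been measured and on what is new or still open speak of the compounds shown alone.

Compound 1 `COc1cc(/C=C2/C(=O)N(C)c3ccc(O)cc32)cc(OC)c1OC` and compound 2 `COc1ccc2c(c1)/C(=C\c1cc(OC)c(OC)c(OC)c1)C(=O)N2C` share one core and differ in a single place. In a functional assay on cells (Cancer cell lines, Homo sapiens) for cytotoxicity, with a stated time of 48 h (on this read-out higher numbers stand for weaker inhibition of growth and lower numbers for stronger inhibition of growth), compound 1 gives 3200 nM. Within the data shown here, compound 2 gives 2700 nM, so the two numbers lie within the usual scatter of each other, and compound 2 stands level with its only measured neighbour.

Compound 3 `COc1ccc(CN2C(=O)/C(=C/c3cc(OC)c(OC)c(OC)c3)c3cc(OC)ccc32)cc1` keeps the core of compound 2 but is altered elsewhere. The change is 4-methoxyphenyl in place of hydrogen on a saturated chain carbon bound to an amide-type nitrogen in a ring, on a saturated chain carbon bound to an amide-type nitrogen in a ring, so methyl becomes 4-methoxybenzyl.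

Among the measured compounds shown here, only one measured step is available, a 1.2-fold lower number from compound 1 to compound 2 (0.07 log units; within the scatter). That swap sits on an oxygen on an aromatic ring, not at the new place, and it stays within the scatter, so it bears on the new group only weakly. For the measured compounds named here, no measured compound shows what a change on the amide-type nitrogen does. With no evidence for a direction, no shift beyond the scatter is expected in this assay, though with real uncertainty either way. The estimated change is a 1.4-fold lower number from compound 2 to compound 3 (0.13 log units; within the scatter). For compound 3 the expected value is 2000 nM, with an estimated range from 400 nM to 10000 nM.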

Compound 3, concentration for 50% growth inhibition: 2600 nM
Compound 3: middle estimate off by 1.3-fold (0.11 log units), on the low side; measured number inside the range.
By their numbers in this assay, from the lowest: compounds 3, 2 and 1 (each within the scatter of the next).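

In this assay the change from methyl to 4-methoxybenzyl, on a saturated chain carbon bound to an amide-type nitrogen in a ring, gives a 1.0-fold lower number from compound 2 to compound 3 (0.02 log units; within the scatter) and so stays within the usual scatter. Among these compounds, this is the first reading at this place, since the earlier step concerned only an oxygen on an aromatic ring. It shows that a group carrying one six-membered aromatic ring of carbon only can stand here without a change in the number that this read-out can tell apart from repeat measurements. Nothing at hand explains why the number holds steady here.

Among the compounds shown here, this single step covers only one group at this place, so it cannot show whether the same holds for other kinds of group, such as a chain ending in an amine or a carboxylic acid, or a plain benzyl without its methoxy. As far as these compounds go, whether the amide hydrogen in place of the methyl would also leave the number level remains open, as does whether the oxygen swap and this change would behave the same way together on another member of the series.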